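Swapping chlorophenyl for pyridyl on two related cores

The source may report more compounds than this note shows. Statements on the series, on what has been measured and on what is new or still open speak of the compounds shown alone.

Compound 1 `C=C1C(=O)[C@]23C[C@@]1(O)CC[C@H]2c1ccc(OS(=O)(=O)c2ccc(C)cc2)c(C)c1[C@@H]3Cn1cc(-c2ccccn2)nn1` and compound 2 `C=C1C(=O)[C@]23C[C@@]1(O)CC[C@H]2c1ccc(OS(=O)(=O)c2ccc(C)cc2)c(C)c1[C@@H]3Cn1cc(-c2ccc(Cl)cc2)nn1` share one core and differ only at the group on the triazole ring. In a functional assay on MCF7 cells (Homo sapiens) for cytotoxicity, read by MTT assay, with a stated time of 4 days (on this read-out lower numbers stand for stronger inhibition and higher numbers for weaker inhibition), compound 1 gives 320 nM, and compound 2 gives 1440 nM. The change between them is pyridin-2-yl in place of 4-chlorophenyl on an aromatic carbon, and it brought a 4.5-fold lower number from compound 2 to compound 1 (0.65 log units; beyond the scatter).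

Compound 3 `Cc1ccc(S(=O)(=O)Oc2ccc3c(c2C)[C@H](Cn2cc(-c4ccc(Cl)cc4)nn2)[C@@]24CC(=O)[C@@](C)(CC[C@@H]32)C4)cc1` is built on a second core; the difference between the two cores is not broken down here. For compound 3 this assay reports only a limit, > 20000 nM, so its true number is not known; this is the limit of > 20000 nM in this assay, at which 1 of the 3 values shown sits. Compound 4 `Cc1ccc(S(=O)(=O)Oc2ccc3c(c2C)[C@H](Cn2cc(-c4ccccn4)nn2)[C@@]24CC(=O)[C@@](C)(CC[C@@H]32)C4)cc1` is the not yet measured partner of compound 3, made by the same change, (pyridin-2-yl in place of 4-chlorophenyl on an aromatic carbon).

The expectation is that this step, an at least 2.2-fold lower number from compound 3 to compound 4 (0.34 log units; beyond the scatter), is estimated to fall near the size seen with compound 1 and compound 2, a 4.5-fold lower number from compound 2 to compound 1 (0.65 log units; beyond the scatter), though because compound 3 gives only the limit of > 20000 nM in this assay, at which 1 of the 3 values shown sits, the starting point is uncertain. Compound 4 is therefore estimated at 9000 nM, with a likely range from 2500 nM to 40000 nM, and a real chance that only a limit is again reported.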

Compound 4, half-maximal inhibitory concentration: > 20000 nM
Compound 4: only a limit was reported; the forecaster's own chance of this, stated with the estimate: 40%; at least 2.2-fold (0.34 log units) between middle value and limit.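

In this assay, compound 3 and compound 4 are both reported only as limits, so the step between them cannot be read: the limit of > 20000 nM in this assay, at which 2 of the 4 values shown sit.

The compounds shown leave open whether pyridin-2-yl in place of 4-chlorophenyl changes anything on the core of compound 3, as it did on the core of compound 1, and what the true numbers of compound 3 and compound 4 are.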